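Swapping diethylamino for methoxymethoxy in the series

The compounds below may be only part of what the source reports. "The series", "measured", "known", "first", "only" and "open" are said of these compounds alone.

Of the compounds shown here, two have numbers so far: compound 1 (`CC(=O)O[C@]1(C)/C=C/C(=O)/C(CO)=C\C[C@](C)(CCC=C(C)C)/C=C/[C@H]1OC(=O)C=C(C)C`) and compound 2 (`CCN(CC)C/C1=C/C[C@](C)(CCC=C(C)C)/C=C/[C@@H](OC(=O)C=C(C)C)[C@](C)(O)/C=C/C1=O`). In a functional assay on SW480 cells (Homo sapiens) for antiproliferative activity, read by MTT assay, with a stated time of 48 h (on this read-out lower numbers stand for stronger inhibition and higher numbers for weaker inhibition), compound 1 gives 2010 nM and compound 2 gives 270 nM on the same read-out. Compound 2 holds the lower of the two numbers, and its gap to compound 1 lies beyond the usual scatter.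

Compound 3 (`COCOC/C1=C/C[C@](C)(CCC=C(C)C)/C=C/[C@@H](OC(=O)C=C(C)C)[C@](C)(O)/C=C/C1=O`) has not yet been measured. It carries methoxymethoxy in place of diethylamino on a saturated chain carbon bound to a double-bonded ring carbon. For the measured compounds named here, no measured pair differs in this one place alone, so the step in this assay has no direct precedent. Going by the values given here, the expectation rests only on compound 1 at 2010 nM as the one other measured number, and it stays loose. The expected step is a 3.3-fold higher number from compound 2 to compound 3 (0.52 log units; beyond the scatter) and points toward weaker inhibition, modestly beyond the scatter. For compound 3 the estimated value is 900 nM with an expected range from 300 nM to 2700 nM in this read-out.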

Compound 3, half-maximal inhibitory concentration: 3710 nM
Beside the measured number, compound 3's estimate is 4.1-fold (0.62 log units) below it, and the stated range ends below it.
By their numbers in this assay, from the lowest: compound 2; then compounds 1 and 3 (each within the scatter of the next).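

In this assay, for the compounds shown here, methoxymethoxy in place of diethylamino on a saturated chain carbon bound to a double-bonded ring carbon gives a 14-fold higher number from compound 2 to compound 3 (1.14 log units; beyond the scatter) and so provides the first direct reading at this place, with the rest of the structure held constant. The result shows that inhibition in this series depends strongly on the group carried here, and that the change is a large loss rather than a neutral exchange. Both groups have no ring, no hydrogen-bond donors and no net charge, so a step of this size does not require a change in any of those three counts, although the data give no reason for it.

Going by these compounds, with only diethylamino and methoxymethoxy compared directly here, it remains open whether another amine, such as pyrrolidine or morpholine, would stay close to compound 2, and whether a plain methoxy group would stay close to compound 3. Compound 1 differs from compound 2 and from compound 3 in more than one place, so it gives no clean reading of how far the nitrogen of the diethylamino group matters at this position.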